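Notes: chloro in place of bromo on aromatic carbon

A few compounds are considered here, and "the series" means these few. Any claim that something is new, unique, unknown or untested is made for them only; others in the source may bear on it.

In a functional assay on thoracic aorta (Rattus norvegicus, strain Wistar), with a stated time of 15 min (a higher number here means that more compound is needed for the effect, a lower number that less compound is needed), compound 1 (`COc1ccc(Cl)cc1C(C)NC(=O)N(C)S(=O)(=O)c1ccc(Cl)cc1`) gives 20000 nM and compound 2 (`COc1ccc(Br)cc1C(C)NC(=O)N(C)S(=O)(=O)c1ccc(C)cc1`) gives 19100 nM on the same read-out. These two values lie within the scatter of each other, so compound 2 stands level with compound 1 and the pair cannot be ranked. Compound 3 (`COc1ccc(Cl)cc1C(C)NC(=O)N(C)S(=O)(=O)c1ccc(C)cc1`) carries chloro in place of bromo on an aromatic carbon, para to a methoxy group and meta to a large group (chloro in place of bromo on an aromatic carbon). For the measured compounds named here, no step between measured compounds shows the effect of any single change so far. The expectation is therefore no step beyond the scatter, with no direction favoured. The estimated 1.0-fold lower number from compound 2 to compound 3 (0.00 log units; within the scatter) is expected to stay within the scatter. Compound 3 is expected at 19000 nM (estimated range 9000 nM to 40000 nM).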

Compound 3, half-maximal effective concentration: 13800 nM
The estimate for compound 3 lay 1.4-fold (0.14 log units) above the measured number; low and high end bracket the measured number.
By their numbers in this assay, from the lowest: compounds 3, 2 and 1 (each within the scatter of the next).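

In this assay, the aromatic carbon para to a methoxy group now has its first single-place comparison: chloro in place of bromo gives a 1.4-fold lower number from compound 2 to compound 3 (0.14 log units; within the scatter) and so does not separate the two halogens. A second single-place comparison, methyl in place of chloro on an aromatic carbon, gives a 1.4-fold lower number from compound 1 to compound 3 (0.16 log units; within the scatter) and likewise leaves the pair level. No measurement at hand accounts for either step.

The compounds shown carry only chloro or bromo at the carbon para to a methoxy group and only methyl or chloro at the other varied carbon, so the effect of an amine or a carboxylic acid at either place remains open. From the compounds shown here alone, whether ethoxy or a longer chain in place of the methoxy group would shift the number also remains open.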